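Oral exposure: the step from compound 1 to compound 3

This account rests on a few compounds, and the source may have more. Where it says the series, first, only, none or still open, it means among the compounds named here.

In an ADME assay on the whole organism (plasma) for pharmacokinetics, with Rattus norvegicus as the target, at a dose of 5 mg/kg by the oral route (a higher number here means more compound in the circulation at the dose given, a lower number less compound in the circulation), compound 1 (`CC[C@H](C)[C@@H]1C(=O)N[C@H](C2Cc3ccccc3C2)C(=O)N1[C@@H](C(=O)N(C)C)c1ccc(C)[n+]([O-])c1`) gives 24 ng.h/mL and stands lowest of the two numbers available. Compound 2 (`CCC(CC)[C@@H]1C(=O)N[C@H](C2Cc3ccccc3C2)C(=O)N1[C@@H](C(=O)N1CCOCC1)c1ccc(C)nc1C`) gives 2330 ng.h/mL and is its nearest neighbour, with the gap between them well beyond the scatter.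

Compound 3 (`CC[C@H](C)[C@@H]1C(=O)N[C@H](C2Cc3ccccc3C2)C(=O)N1[C@@H](C(=O)N(C)C)c1cc(C)cnc1C`) keeps the rest of compound 1 and exchanges one group: a group of 8 heavy atoms (7 carbon, 1 nitrogen; one six-membered aromatic ring with 1 hetero atom) in place of a group of 8 heavy atoms (6 carbon, 1 nitrogen, 1 oxygen; one six-membered aromatic ring with 1 hetero atom), on a saturated chain carbon bound to an amide-type nitrogen in a ring and a carbonyl carbon (the entering group is 2,5-dimethylpyridin-3-yl). The exchange sits on a saturated chain carbon bound to an amide-type nitrogen in a ring and a carbonyl carbon.

Within the data shown here, no measured pair isolates this exchange, so any expectation rests on two values only and remains loose. Among the measured compounds shown here, compound 1 lies at the bottom of the range seen so far, and the only other number is far higher. In this assay an upward move beyond the scatter is expected, estimated as a 29-fold higher number from compound 1 to compound 3 (1.46 log units; beyond the scatter) with wide uncertainty. The estimate stays under the top of the range seen so far, though the upper end of its range passes it. For compound 3 the expected value is 700 ng.h/mL with an estimated range of 150 ng.h/mL to 3000 ng.h/mL until a measurement is available.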

Compound 3, area under the concentration-time curve: 1370 ng.h/mL
Estimate against measurement, compound 3: 2.0-fold (0.29 log units) below; the measured number falls inside the stated range.
By their numbers in this assay, from the lowest: compound 1; then compounds 3 and 2 (each within the scatter of the next).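

In this assay, the exchange on a saturated chain carbon bound to an amide-type nitrogen in a ring and a carbonyl carbon gives a 57-fold higher number from compound 1 to compound 3 (1.76 log units; beyond the scatter), with the rest of the molecule held constant, so this position alone can carry a large step. Heavy-atom count, ring type, hydrogen-bond donors and acceptors and net charge are the same in the leaving group and in 2,5-dimethylpyridin-3-yl, so none of these counts tells the two groups apart; they differ in atom make-up, with 6 carbon, 1 nitrogen and 1 oxygen leaving and 7 carbon and 1 nitrogen entering. Nothing measured on the compounds bears on what lies behind the step.

Among these compounds, the single step does not separate the loss of the oxygen from the other differences between the two groups, and it says nothing about how far the result extends to other groups at this carbon. A plain phenyl ring or an unsubstituted pyridin-3-yl on the same carbon, read in this assay, would test whether the step depends on the ring nitrogen or on the methyl groups of the entering group.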